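This account rests on a few compounds, and the source may have more. Where it says the series, first, only, none or still open, it means among the compounds named here.

Within the data shown here, in a functional assay on B16 cells (Mus musculus) for cytotoxicity, read by MTT assay, with a stated time of 72 h (a higher number here means a weaker inhibitor, a lower number a stronger inhibitor), compound 2 `COc1cccc(/C=C/C(=O)Nc2cc(C(=O)c3cc(OC)c(OC)c(OC)c3)ccc2OC)c1` gives 3100 nM, the lowest of the two numbers known so far. Compound 1 `COc1cccc(/C=C/C(=O)Nc2cc(OC)c(OC)c(OC)c2)c1` gives 8500 nM in this assay, a higher number that lies beyond the usual scatter. Compound 3 `COc1cc(/C=C/C(=O)Nc2cc(C(=O)c3cc(OC)c(OC)c(OC)c3)ccc2OC)ccc1F` differs from compound 2 by fluoro in place of hydrogen on an aromatic carbon. Among the measured compounds shown here, no measured pair in this set shows such a change, so its size can only be guessed. The expected step of a 1.1-fold lower number from compound 2 to compound 3 (0.04 log units; within the scatter) is small, within the scatter, in either direction. Compound 3 is therefore estimated at 2800 nM in this assay, with a range from 1200 nM to 7000 nM.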

Compound 3, half-maximal inhibitory concentration: 16300 nM
Compound 3: middle estimate off by 5.8-fold (0.77 log units), on the low side; the measured number lies above the stated range.
By their numbers in this assay, from the lowest: compound 2; then compounds 1 and 3 (each within the scatter of the next).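

Turning the 3-methoxyphenyl into 4-fluoro-3-methoxyphenyl is not a neutral change in this assay: a single fluoro on this aromatic carbon, ortho to a methoxy group, gives a 5.3-fold higher number from compound 2 to compound 3 (0.72 log units; beyond the scatter) and so a weaker inhibitor. Among these compounds, this is the first sign that this carbon responds to substitution at all. Nothing measured here accounts for the loss. On these data alone, what a chloro, a methyl or an amine on this same carbon would give stays open. Also open, as far as these compounds go, is whether fluoro on another carbon of this ring would bring a like step.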